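Working notes: methoxy to fluoro step, cytotoxicity on BV-2 cells

The compounds below may be only part of what the source reports. "The series", "measured", "known", "first", "only" and "open" are said of these compounds alone.

Measured so far in an ADME assay on BV-2 cells (Mus musculus) for cytotoxicity, with a stated time of 24 h, tested at 50 uM; a higher number here means a weaker effect of the compound at the concentration tested, a lower number a stronger effect:
compound 1, `COc1ccccc1S(=O)(=O)/C=C/c1ccc(Cl)nc1Cl`: 99.8%
compound 2, `COc1ccccc1/C=C/S(=O)(=O)c1ccccn1`: 93.4%

Both numbers sit near the top of the scale, so neither compound shows much effect at the concentration tested. Compound 2 has the lower of the two numbers; compound 1 lies higher by an amount that is within the usual scatter of this kind of measurement, so the two readings cannot be placed in any order, and neither compound can be called the stronger or the weaker.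

The next compound, compound 3 `O=S(=O)(/C=C/c1ccccc1F)c1ccccn1`, has not yet been measured. Its difference from compound 2 is a single change: fluoro in place of methoxy on an aromatic carbon. Going by the values given here, no pair of measured compounds differing in one place is available, so there is no measured step to lean on; the expectation rests only on the two readings above, which both lie close to the top of the scale.

For this assay the step from compound 2 to compound 3 is expected to be small, most likely none beyond the scatter, and is estimated as a number 1.6 percentage points higher from compound 2 to compound 3 (within the scatter). Compound 3 is therefore estimated at 95%, expected to fall between 80% and 102%.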

Compound 3, a percentage reported as activity, at one concentration (the size of the read-out at that concentration, not a potency): 98.6%
Compound 3: the middle estimate sits 3.6 percentage points below what was measured; low and high end bracket the measured number.
By their numbers in this assay, from the lowest: compounds 2, 3 and 1 (each within the scatter of the next).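

In this assay the series now has its first measured step between compounds that differ in one place: fluoro in place of methoxy on an aromatic carbon, ortho to a large group, gives a number 5.2 percentage points higher from compound 2 to compound 3 (within the scatter) and so no change that can be told from the scatter. At this position on the core of compound 2, the methoxy group, with its 2 heavy atoms and 1 hydrogen-bond acceptor, can therefore give way to a single fluorine with no resolved shift in the reading, and compound 3 stays near the top of the scale. Nothing measured on these compounds offers an explanation for this flat step.

From the compounds shown here alone, only this one replacement has been read at this position, so it remains open whether a group such as an amine, a carboxylic acid or a longer chain would leave the reading equally flat. Going by these compounds, it also remains open whether the same fluoro for methoxy change would behave this way on another core, since a single step at one concentration in this assay says nothing about any other setting.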